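A few compounds are considered here, and "the series" means these few. Any claim that something is new, unique, unknown or untested is made for them only; others in the source may bear on it.

The study compares three measured compounds in an assay on membranes from brain for displacement of a labelled ligand from Sigma non-opioid intracellular receptor 1 (Cavia porcellus), read by scintillation counting, with a stated time of 120 min (a higher number here means a weaker inhibitor, a lower number a stronger inhibitor), and one compound that is still to be measured there. Compound 1 `N#Cc1ccc(-c2scc3c2CCOC32CCN(Cc3ccccc3)CC2)cc1` gives 3.4 nM in this assay. Compound 2 `COC1Cc2cscc2C2(CCN(Cc3ccccc3)CC2)O1` gives 0.22 nM in this assay. Compound 3 `c1ccc(CN2CCC3(CC2)OCCc2cc(-c4ccccc4)sc23)cc1` gives 2.4 nM in this assay, the second highest of the three numbers: it sits nearest to compound 1, within the scatter, and furthest from compound 2, whose number is lower by a gap beyond the scatter.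

Compound 4 `COC1Cc2cc(-c3ccccc3)sc2C2(CCN(Cc3ccccc3)CC2)O1` differs from compound 3 in one place, (methoxy in place of hydrogen on a saturated ring carbon). For the measured compounds named here, no measured pair shows this change on its own. Going by the values given here, compound 2 carries the same methoxy without the phenyl and is the one with the lowest number, so a modest move towards lower numbers is expected, though the two compounds differ in more than one place and the step may not exceed the scatter. For compound 4 the estimate in this assay is 1 nM, with a range from 0.3 nM to 4 nM, which would mean an expected step of a 2.4-fold lower number from compound 3 to compound 4 (0.38 log units; beyond the scatter).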

Compound 4, inhibition constant: 16 nM
Compound 4: middle estimate off by 16-fold (1.20 log units), on the low side, and the stated range ends below it.
By their numbers in this assay, from the lowest: compound 2; then compounds 3 and 1 (each within the scatter of the next); then compound 4.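

In this assay, for the compounds shown here, methoxy in place of hydrogen on this saturated ring carbon, next to the ring oxygen, is seen on its own for the first time, and it gives a weaker inhibitor (a 6.7-fold higher number from compound 3 to compound 4 (0.82 log units; beyond the scatter)). On the phenyl-bearing core of compound 3, this position therefore does not take the methoxy without loss, and the low number of compound 2, which differs from compound 4 in more than one place, does not carry over to this pair. Nothing measured here gives a reason for the loss.

From the compounds shown here alone, it remains open whether the loss belongs to the methoxy itself or to any group on this carbon, a question that a hydroxyl or an ethoxy there would address. Going by these compounds, it also remains open whether the same change behaves alike on a core without the phenyl.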